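A few compounds are considered here, and "the series" means these few. Any claim that something is new, unique, unknown or untested is made for them only; others in the source may bear on it.

Compound 1 `CCOc1ccccc1-n1nncc1CN1C(=O)C2(C(C#N)=C(N)Oc3c2c2nc4ccccc4nc2c2ccccc32)c2ccccc21` — > 50000 nM
Compound 2 `N#CC1=C(N)Oc2c(N)cc3nc4ccccc4nc3c2C12C(=O)N(Cc1cnnn1-c1ccc(F)cc1)c1ccccc12` — > 50000 nM

Both compounds were tested in an ADME assay on L02 cells (Homo sapiens) for antiproliferative activity, read by MTT assay, with a stated time of 48 h; on this read-out lower numbers stand for stronger inhibition and higher numbers for weaker inhibition. For compound 1 the value > 50000 nM is a limit of the assay rather than a number. For compound 2 the value > 50000 nM is likewise a limit and not a number. Compound 2 therefore stands at the limit of > 50000 nM in this assay, at which 2 of the 2 values shown sit, and nothing measured here separates it from compound 1. For the measured compounds named here, no step between the two can be given a size, since neither value is a number.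

Compound 3 `N#CC1=C(N)Oc2c(N)cc3nc4ccccc4nc3c2C12C(=O)N(Cc1cnnn1-c1ccccc1Br)c1ccccc12` has not yet been tested in this assay. It differs from compound 2 in one place: 2-bromophenyl in place of 4-fluorophenyl on an aromatic nitrogen. Going by the values given here, with both measured compounds sitting at the limit, there is no measured step to lean on, and the expectation is that this change produces no step beyond the scatter. Compound 3 is expected to give 60000 nM, with a range from 25000 nM to 150000 nM, most likely reported again as a limit. The step from compound 2 to compound 3 is estimated as a step that the limit leaves unreadable from compound 2 to compound 3.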

Compound 3, half-maximal inhibitory concentration: 29200 nM
The estimate for compound 3 lay 2.1-fold (0.31 log units) above the measured number, within the range that was stated.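

In this assay, putting 2-bromophenyl in place of 4-fluorophenyl on the aromatic nitrogen of the triazole ring gives an at least 1.7-fold lower number from compound 2 to compound 3 (0.23 log units; that floor lies within the scatter). For the compounds shown here, this is the first sign that a change at this position can bring a compound of this kind into the range where the assay returns a number, although the smallest step the data allow is not enough on its own to show a real difference. The true size of the step stays unknown because the value for compound 2 is a limit and not a number, so only a floor can be stated: the limit of > 50000 nM in this assay, at which 2 of the 3 values shown sit.

The change alters both the halogen and its place on the phenyl ring, so these compounds cannot show whether the bromine, its place or the two together go with the measured number. A 2-fluorophenyl or a 4-bromophenyl group on the same nitrogen would separate those two features, and a 2-aminophenyl group would show whether a halogen is needed there at all.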